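The source may hold more compounds than are shown below. What is called first, only, known or untested is meant among the compounds shown, and "the series" means these compounds.

Compound 2 `CS(=O)(=O)N1CC(CCl)c2cc(Br)c(O)cc21` carries a bromo group on the shared core of these compounds. In a functional assay on KB cells (Homo sapiens), read by crystal violet staining (a lower number here means a stronger inhibitor, a higher number a weaker inhibitor), compound 2 gives 3.8 ug/mL, while compound 1 `CS(=O)(=O)N1CC(CCl)c2ccc(O)cc21` gives 4.24 ug/mL, a gap that lies within the usual scatter of this measurement. Within the data shown here, the only measured step, a 1.1-fold lower number from compound 1 to compound 2 (0.05 log units; within the scatter), changed the same aromatic carbon and made no real difference. Compound 3 `CS(=O)(=O)N1CC(CCl)c2cc([N+](=O)[O-])c(O)cc21` takes the next step: nitro in place of bromo on an aromatic carbon. Because the earlier step of a 1.1-fold lower number from compound 1 to compound 2 (0.05 log units; within the scatter) stayed within the scatter, compound 3 is expected to move little, a 1.1-fold higher number from compound 2 to compound 3 (0.02 log units; within the scatter). In this assay compound 3 is therefore estimated at 4 ug/mL, with a likely range from 2 ug/mL to 8 ug/mL.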

Compound 3, half-maximal inhibitory concentration: 8.85 ug/mL
Beside the measured number, compound 3's estimate is 2.2-fold (0.34 log units) below it, and the stated range ends below it.
By their numbers in this assay, from the lowest: compounds 2 and 1 (each within the scatter of the next); then compound 3.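

On this aromatic carbon, ortho to a hydroxy group, the choice of group does matter in this assay: nitro in place of bromo gives a 2.3-fold higher number from compound 2 to compound 3 (0.37 log units; beyond the scatter), and nitro in place of hydrogen gives a 2.1-fold higher number from compound 1 to compound 3 (0.32 log units; beyond the scatter). Bromo had made no real difference, so this position is not indifferent to every group, and compound 3 is the weakest inhibitor of the three. Nothing available explains this shift. From the compounds shown here alone, it remains open whether an amine or a methoxy group on this carbon would behave like bromo or like nitro.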